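Chloro for Trifluoromethyl at the Cytotoxicity Limit

The compounds below may be only part of what the source reports. "The series", "measured", "known", "first", "only" and "open" are said of these compounds alone.

Compound 1 `CC(C)N(Cc1cccc(OCCCCCC(=O)O)c1)C(=O)c1ccc(-c2cccc(OC(F)(F)F)c2)cc1`: > 26000 nM in an ADME assay on HepG2 cells (Homo sapiens) for cytotoxicity, read by CellTiter-Glo and resazurin assay, with a stated time of 72 h (a higher number here means that more compound is needed for the effect, a lower number that less compound is needed), a limit of the assay rather than a number.
Compound 2 `CC(C)N(Cc1cccc(OCCCCCC(=O)O)c1)C(=O)c1ccc(-c2cccc(C(F)(F)F)c2)cc1`: in this assay compound 2 gives > 26000 nM, likewise only a limit.

Both measured values are limits, so the step that the two limits leave unreadable from compound 1 to compound 2 cannot be read; (the limit of > 26000 nM in this assay, at which 2 of the 2 values shown sit). Compound 3 `CC(C)N(Cc1cccc(OCCCCCC(=O)O)c1)C(=O)c1ccc(-c2cccc(Cl)c2)cc1` differs from compound 2 by chloro in place of trifluoromethyl on an aromatic carbon. Within the data shown here, only that unreadable step bears on this change, so no shift beyond the scatter can be foreseen. The step is expected to be a step that the limit leaves unreadable from compound 2 to compound 3. Compound 3 is estimated at 30000 nM, with a range from 12000 nM to 90000 nM, most likely again only a limit.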

Compound 3, half-maximal effective concentration: > 21900 nM
Compound 3 gave a limit, no number; the forecaster's own chance of this, stated with the estimate: 75%; the middle value lies beyond the limit too.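

Among these compounds, compound 1, compound 2 and compound 3 all give only limits in this assay, so no step among them can be read. Going by these compounds, the concentration at which any of them reaches the half-maximal effect stays open.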